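Ring variation on the imidazole of a biphenyl acid series

The compounds below may be only part of what the source reports. "The series", "measured", "known", "first", "only" and "open" are said of these compounds alone.

Measured so far:
compound 1 `O=C(O)c1ccccc1-c1ccc(CCc2ncc(CC3CCCCC3)[nH]2)cc1` — 7.3 nM
compound 2 `O=C(O)c1ccccc1-c1ccc(CCc2ncc(CC3CCC3)[nH]2)cc1` — 7.1 nM
compound 3 `O=C(O)c1ccccc1-c1ccc(CCc2ncc(C3CCCCC3)[nH]2)cc1` — 14.7 nM

All three share the same core and differ only in the group on the imidazole carbon. In an in vitro functional assay on cells for agonist activity at Bombesin receptor subtype-3 (Mus musculus), read by luminescence and calcium flux (on this read-out lower numbers stand for an effect already at smaller amounts and higher numbers for an effect only at larger amounts of compound), compound 1 gives 7.3 nM, compound 2 gives 7.1 nM and compound 3 gives 14.7 nM. Compound 3 thus has the highest number of the three, although a 2.0-fold higher number from compound 1 to compound 3 (0.30 log units; within the scatter) stays within the scatter; only a 2.1-fold higher number from compound 2 to compound 3 (0.32 log units; beyond the scatter) reaches just beyond it. Swapping the saturated ring size while keeping the linking carbon changed nothing: a 1.0-fold lower number from compound 1 to compound 2 (0.01 log units; within the scatter).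

Compound 4 `Cc1ccccc1Cc1cnc(CCc2ccc(-c3ccccc3C(=O)O)cc2)[nH]1` is not yet measured. Its change from compound 3 is 2-methylbenzyl in place of cyclohexyl on an aromatic carbon. The step bears resemblance to the reverse of the two steps into compound 3, since cyclohexylmethyl, cyclobutylmethyl and 2-methylbenzyl all present a ring through a saturated carbon, and those two steps were small. Within the data shown here, no measured compound carries an aromatic ring or a methyl at this position, so that part of the change is uninformed. Compound 4 is therefore expected to come out with a number near those of compounds 1 and 2, so that a 1.8-fold lower number from compound 3 to compound 4 (0.26 log units; within the scatter) is the expected step, and the estimate for compound 4 in this assay is 8 nM with a range of 3 nM to 25 nM.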

Compound 4, half-maximal effective concentration: 9.3 nM
Compound 4: middle estimate off by 1.2-fold (0.07 log units), on the low side; low and high end bracket the measured number.
By their numbers in this assay, from the lowest: compounds 2, 1, 4 and 3 (each within the scatter of the next, the first and the last beyond it).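

In this assay, among these compounds, 2-methylbenzyl on this aromatic carbon of the five-membered aromatic ring with 2 nitrogen gives compound 4, the first compound here with an aromatic ring and a methyl in the group at this place, and the number stays within the scatter of all three saturated-ring compounds: a 1.6-fold lower number from compound 3 to compound 4 (0.20 log units; within the scatter), a 1.3-fold higher number from compound 2 to compound 4 (0.12 log units; within the scatter) and a 1.3-fold higher number from compound 1 to compound 4 (0.11 log units; within the scatter). The change from a six-membered non-aromatic ring to a six-membered aromatic ring on a saturated carbon therefore leaves no readable mark on this read-out, at least for the cyclohexylmethyl and 2-methylbenzyl pair. Compound 4 also adds no new extreme to the set, so the only gap beyond the scatter remains the modest one between compound 2 and compound 3, and nothing available here accounts for this tolerance.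

The ring and the methyl of 2-methylbenzyl enter together, so the share of each stays unresolved, and a plain benzyl would be needed to separate them. Also open, from the compounds shown here alone, is whether this place still accepts a group carrying an amine or a carboxylic acid, or a longer chain between the ring and the aromatic carbon.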